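From a Carboxy Chain to a Carbamoyl Group

This account rests on a few compounds, and the source may have more. Where it says the series, first, only, none or still open, it means among the compounds named here.

Compound 1 `C=CCCn1cnc2c1c(=O)n(C)c(=O)n2CCC`: 6000 nM
Compound 2 `CCCn1c(=O)n(C)c(=O)c2c1ncn2CCC(=O)O`: > 200000 nM, a limit

In an assay on Cerebral cortex for binding affinity to adenosine receptor A1 (Cavia porcellus), read by radioligand binding (on this read-out lower numbers stand for stronger inhibition and higher numbers for weaker inhibition), compound 1 gives 6000 nM. For compound 2 the assay reports only a limit, > 200000 nM, not a number. For the measured compounds named here, the single measured step, an at least 33-fold higher number from compound 1 to compound 2 (1.52 log units; beyond the scatter), thus went strongly toward weaker binding, and compound 2 stands at the weak end of what this assay can resolve (the limit of > 200000 nM in this assay, at which 1 of the 2 values shown sits).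

Compound 3 `CCCn1c(=O)n(C)c(=O)c2c1ncn2CC(N)=O` differs from compound 2 by carbamoyl in place of carboxymethyl on a saturated chain carbon bound to an aromatic nitrogen. The measured step speaks only indirectly here: it shows that a carboxy chain at this position is poorly tolerated, but it gives no reading for a carbamoyl group in its place. Some recovery toward compound 1 is plausible, yet unproven.

Compound 3 is therefore expected to give about 80000 nM, estimated between 15000 nM and 400000 nM. The estimate implies an expected step of an at least 2.5-fold lower number from compound 2 to compound 3 (0.39 log units; beyond the scatter).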

Compound 3, inhibition constant: > 200000 nM
Compound 3: no number, only a limit; the forecaster's own chance of this, stated with the estimate: 40%; at least 2.5-fold (0.39 log units) between middle value and limit.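

In this assay, compound 3 gives > 200000 nM, which is a limit and not a number. The carbamoyl group also comes with a large loss, an at least 33-fold higher number from compound 1 to compound 3 (1.52 log units; beyond the scatter), so weak binding at this position is not confined to the carboxy chain. The step between compound 2 and compound 3 cannot be read, and any difference between them stays hidden at the weak end of the assay: the limit of > 200000 nM in this assay, at which 2 of the 3 values shown sit.

From the compounds shown here alone, how far past the limit each of these two compounds lies remains unknown, so the carboxy chain and the carbamoyl group cannot be ranked against each other. Also open, going by these compounds, is whether an amine or a longer plain carbon chain in this place would keep binding closer to compound 1, which gives 6000 nM.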